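The compounds below may be only part of what the source reports. "The series", "measured", "known", "first", "only" and "open" are said of these compounds alone.

Measured so far in an ADME assay on L02 cells (Homo sapiens) for cytotoxicity, read by MTT assay, with a stated time of 72 h; on this read-out higher numbers stand for weaker inhibition and lower numbers for stronger inhibition:
Compound 1, `CCC/C=C/C(=O)Nc1cccc(Oc2nc(Nc3cccc(OC)c3)nc3c2CSCC3)c1`, gives > 50000 nM, a limit of the assay and not a number.
Compound 2, `COc1cccc(Nc2nc3c(c(Oc4cccc(NC(=O)C=C(C)C)c4)n2)CSCC3)c1`, gives > 50000 nM, again a limit.
Compound 3, `CCC/C=C/C(=O)Nc1cccc(Oc2nc(Nc3ccc(OC)cc3)nc3c2CSCC3)c1`, gives > 50000 nM, once more a limit.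

Compound 1 and compound 2 differ by 2-methylprop-1-en-1-yl in place of pent-1-en-1-yl on a carbonyl carbon, and the step that the two limits leave unreadable from compound 1 to compound 2 cannot be sized. The two cores differ by 4-methoxyphenyl in place of 3-methoxyphenyl on a nitrogen on an aromatic ring, and the step that the two limits leave unreadable from compound 1 to compound 3 is equally unreadable. Compound 4, `COc1ccc(Nc2nc3c(c(Oc4cccc(NC(=O)C=C(C)C)c4)n2)CSCC3)cc1`, has not yet been tested. It differs from compound 3 by 2-methylprop-1-en-1-yl in place of pent-1-en-1-yl on a carbonyl carbon, which is the same change made from compound 1 to compound 2, at a place described in the same words. Any expectation for compound 4 rests on (the limit of > 50000 nM in this assay, at which 3 of the 3 values shown sit), since every tested partner stopped there. Compound 4 is expected to give about 60000 nM in this assay, with the range 30000 nM to 150000 nM. For compound 4 the expected step is a step that the limit leaves unreadable from compound 3 to compound 4, most likely reported only as a limit rather than a number.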

Compound 4, half-maximal inhibitory concentration: > 50000 nM
Compound 4 gave a limit, no number (the forecaster's own chance of this, stated with the estimate: 85%); the middle value does not contradict the limit.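

Compound 4, like compound 2 and compound 3, gives only a limit in this assay, so neither the step from compound 3 to compound 4 nor the step from compound 2 to compound 4 can be read. The compounds shown leave open whether either change shifts this read-out at all, and what number any of the four would give.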